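The source may report more compounds than this note shows. Statements on the series, on what has been measured and on what is new or still open speak of the compounds shown alone.

The account follows two compounds that share one core and differ only in the group placed on the exocyclic carbonyl. Compound 1 `CC1(C)S[C@@H]2/C(=C\C(=O)OC(c3ccccc3)c3ccccc3)C(=O)N2[C@H]1C(=O)OC(c1ccccc1)c1ccccc1` carries a benzhydryl ester there, and in a functional assay on OE19 cells (Homo sapiens) for cytotoxicity, read by MTT assay, with a stated time of 48 h (a lower number here means a stronger inhibitor, a higher number a weaker inhibitor), compound 1 gives 21600 nM. Compound 2 `CC(=O)/C=C1/C(=O)N2[C@@H]1SC(C)(C)[C@@H]2C(=O)OC(c1ccccc1)c1ccccc1` carries a simple acetyl group instead, and in this assay compound 2 gives 51900 nM. Of the two numbers now known, compound 2 stands at the higher one; the gap to compound 1 lies beyond the scatter of repeated measurements, so compound 2 is the weaker of the two as measured.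

Compound 3 `CC1(C)S[C@@H]2/C(=C\C(=O)c3cc(F)cc(F)c3)C(=O)N2[C@H]1C(=O)OC(c1ccccc1)c1ccccc1` keeps the core of compound 2 and changes the acetyl end: 3,5-difluorophenyl in place of methyl on a carbonyl carbon. Among the compounds with values here, no measured pair shows exactly this step, so the direction can only be inferred from the two values at hand. Since compound 1, with its larger aromatic ester, gave 21600 nM, a move from the small methyl to an aromatic ring at the same carbonyl is expected to shift the number downward by a modest margin, a 2.1-fold lower number from compound 2 to compound 3 (0.32 log units; beyond the scatter). On that basis compound 3 is estimated at 25000 nM in this assay, within a range from 8000 nM to 80000 nM.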

Compound 3, half-maximal inhibitory concentration: 17600 nM
Estimate against measurement, compound 3: 1.4-fold (0.15 log units) above; the measured number falls inside the stated range.
By their numbers in this assay, from the lowest: compounds 3 and 1 (each within the scatter of the next); then compound 2.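

The carbonyl carbon whose other neighbour is the double-bonded chain carbon now has its first direct reading: with 3,5-difluorophenyl in place of methyl, this assay shows a 2.9-fold lower number from compound 2 to compound 3 (0.47 log units; beyond the scatter), a modest step but one beyond the scatter. Within the data shown here, until now, the only comparison set a benzhydryl ester against an acetyl group, whereas this pair shows that an aromatic ring placed directly on that carbonyl carbon also gives a lower number than methyl does, and the numbers of compound 3 and compound 1 lie within the scatter of each other. Nothing available here speaks to what lies behind this step.

From the compounds shown here alone, whether the step belongs to the ring itself or to its two fluorines stays open, and a plain phenyl on the same carbonyl carbon would separate the two. Going by these compounds, how an amine or a longer alkyl chain at that carbon would read in this assay also stays open, as does whether the step would hold on a core carrying a carboxylic acid in place of the benzhydryl ester.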